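The compounds below may be only part of what the source reports. "The series", "measured", "known", "first", "only" and "open" are said of these compounds alone.

Two analogues built on one shared core were measured in an ADME assay on Huh-7 cells (Homo sapiens) for cytotoxicity, read by a luciferase reporter and WST assay, with a stated time of 3 days; a lower number here means that less compound is tolerated, a higher number that more compound is tolerated. Compound 1 `O=C(Nc1ccccc1)c1c(NO)cc(-c2ccc(Cl)cc2)oc1=O` gives 11000 nM. Compound 2 `O=C(NCCO)c1c(NO)cc(-c2ccccc2)oc1=O` gives > 20000 nM, which is a limit of the assay rather than a number, so compound 2 stands at the limit of > 20000 nM in this assay, at which 1 of the 2 values shown sits. Compound 3 `O=C(NCCO)c1c(NO)cc(-c2ccc(Cl)cc2)oc1=O` is not yet measured; it differs from compound 2 by chloro in place of hydrogen on an aromatic carbon. Going by the values given here, with no measured step of this kind to draw on, the expected step is an at least 1.3-fold lower number from compound 2 to compound 3 (0.12 log units; that floor lies within the scatter), little or nothing beyond the scatter. For compound 3 the estimate is 15000 nM, ranging from 6000 nM to 40000 nM.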

Compound 3, half-maximal cytotoxic concentration: > 20000 nM
Compound 3: no number, only a limit; the forecaster's own chance of this, stated with the estimate: 50%; middle value at least 1.3-fold (0.12 log units) away from the limit.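

In this assay, compound 3 shows that 4-chlorophenyl in place of phenyl leaves the 2-hydroxyethyl amide at the limit of the assay: the limit of > 20000 nM in this assay, at which 2 of the 3 values shown sit.

The step for chloro in place of hydrogen cannot be read, as both ends are limits. With 4-chlorophenyl held fixed, 2-hydroxyethyl in place of phenyl on the amide-type nitrogen gives an at least 1.8-fold higher number from compound 1 to compound 3 (0.25 log units; that floor lies within the scatter).

On these data alone, how far chloro shifts the read-out beneath the limit stays open. So does whether an amine, a carboxylic acid or a longer chain on the amide nitrogen would stay at the limit.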